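The source may hold more compounds than are shown below. What is called first, only, known or untested is meant among the compounds shown, and "the series" means these compounds.

Measured so far:
compound 1 `Cc1ccccc1-n1nc(-c2ccccc2)nc1CNc1ccc(C(=O)NO)cc1` — 57.1%
compound 2 `O=C(NO)c1ccc(NCc2nc(-c3ccc(Br)o3)nn2-c2ccccc2)cc1` — 55.8%

In an assay on Sf9 cells for inhibition of protein deacetylase HDAC6 (Homo sapiens), read by fluorescence, with a stated time of 40 min, tested at 100 nM (a higher number here means more inhibition at the concentration tested (going by the name of the read-out), a lower number less inhibition), compound 1 gives 57.1% and compound 2 gives 55.8%; the two numbers lie within the usual scatter of each other, so neither is read as set apart. Compound 3 `COc1ccc(-c2nc(CNc3ccc(C(=O)NO)cc3)n(-c3ccccc3)n2)cc1` is not yet measured. It differs from compound 2 by 4-methoxyphenyl in place of 5-bromofuran-2-yl on an aromatic carbon. Among the compounds with values here, no step between measured compounds is known, so there is no precedent for the size of this change; the expectation for a number 0.8 percentage points lower from compound 2 to compound 3 (within the scatter) is a step of no clear direction, not beyond the scatter. Compound 3 is estimated at 55%, within 40% to 68%.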

Compound 3, a percentage reported as inhibition, at one concentration (the size of the read-out at that concentration, not a potency): 77.6%
Beside the measured number, compound 3's estimate is 22.6 percentage points below it, outside the stated range (above it).
By their numbers in this assay, from the lowest: compounds 2 and 1 (each within the scatter of the next); then compound 3.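

In this assay, 4-methoxyphenyl in place of 5-bromofuran-2-yl gives a number 21.8 percentage points higher from compound 2 to compound 3 (beyond the scatter), the first step read in this series, so the group on this aromatic carbon of the five-membered ring with 3 nitrogen can shift the read-out. The two groups have equal counts of hydrogen-bond donors and acceptors, so those counts do not separate them. Nothing available explains the step.

Still open, going by these compounds, is which part of the change carries the step: the methoxy group, the bromine or the ring. Furan-2-yl without bromine and 4-methylphenyl on this carbon would help separate these.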